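The source may hold more compounds than are shown below. What is called first, only, known or untested is meant among the compounds shown, and "the series" means these compounds.

In a functional assay on HCT-116 cells (Homo sapiens) for cytotoxicity, read by MTT assay (a lower number here means a stronger inhibitor, a higher number a weaker inhibitor), compound 1 `COc1cc(CCCCC(C)(C)O)oc(=O)c1C` gives > 200000 nM, which is a limit of the assay and not a number. In this assay compound 2 `Cc1c(O)cc(CCCCC(C)C)oc1=O` gives > 200000 nM, again a limit. In this assay compound 3 `CCC(C)CCCCc1cc(O)c(C)c(=O)o1` gives > 200000 nM, also a limit.

This account follows the step from compound 3 to compound 4 `CC(=O)C(C)CCCCc1cc(O)c(C)c(=O)o1` in this assay. Compound 3 stands at the limit together with the other two measured compounds (the limit of > 200000 nM in this assay, at which 3 of the 3 values shown sit); no numbered value separates any of them. For the measured compounds named here, the only measured step, a step that the two limits leave unreadable from compound 2 to compound 3, is a methyl in place of hydrogen on a saturated chain carbon, six bonds along the chain from an aromatic carbon, and its size cannot be read; both of its ends are limits. The change to compound 4 is acetyl in place of ethyl on a saturated chain carbon bound to two saturated chain carbons. Going by the values given here, no measured step bears on an acetyl entering in place of an ethyl, so the expectation rests only on the limit shared by all three compounds (the limit of > 200000 nM in this assay, at which 3 of the 3 values shown sit). Compound 4 is therefore expected to sit at or near that same limit, and a step that the limit leaves unreadable from compound 3 to compound 4 is expected to be no larger than the scatter. The estimate for compound 4 is 250000 nM, with a range from 50000 nM to 1000000 nM.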

Compound 4, half-maximal inhibitory concentration: > 200000 nM
Compound 4 ended at the assay's limit; the forecaster's own chance of this, stated with the estimate: 75%; the middle value is on the limit's open side.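

In this assay, for the compounds shown here, no step from compound 2 or compound 3 to compound 4 can be read, since all three sit at a limit and not at a number: the limit of > 200000 nM in this assay, at which 4 of the 4 values shown sit.

The compounds shown leave open whether these chain groups differ at all in this assay and what would bring any compound to a numbered value.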